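The source may hold more compounds than are shown below. What is called first, only, known or untested is meant among the compounds shown, and "the series" means these compounds.

- compound 1 `O=C(/C=C/c1ccccc1O)CC(=O)/C=C/c1cccc(O)c1O` gives 23000 nM
- compound 2 `O=C(/C=C/c1ccc(O)cc1)CC(=O)/C=C/c1cccc(O)c1O` gives 27000 nM
- compound 3 `O=C(/C=C/c1ccccc1O)CC(=O)c1ccc(O)c(O)c1` gives 16000 nM

All three values come from a functional assay, with a stated time of 30 min (a higher number here means a weaker inhibitor, a lower number a stronger inhibitor), and compound 3 lies within the usual scatter of both other compounds. Compound 4 `O=C(/C=C/c1cc(O)ccc1O)CC(=O)c1ccc(O)c(O)c1` differs from compound 3 by hydroxy in place of hydrogen on an aromatic carbon, with hydroxy in place of hydrogen on an aromatic carbon, para to a hydroxy group. Going by the values given here, no measured step adds a hydroxy group. The nearest evidence moves one around an aromatic ring, a 1.2-fold higher number from compound 1 to compound 2 (0.07 log units; within the scatter), and that change stays within the scatter. No change beyond the scatter is therefore expected in this assay, in either direction. The estimated step is a 1.2-fold lower number from compound 3 to compound 4 (0.09 log units; within the scatter). Compound 4 is expected at 13000 nM, with an estimated range from 5000 nM to 28000 nM.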

Compound 4, half-maximal inhibitory concentration in the functional assay: 82000 nM
Compound 4: the middle estimate sits 6.3-fold (0.80 log units) below what was measured; the measured number lies above the stated range.
By their numbers in the functional assay, from the lowest: compounds 3, 1 and 2 (each within the scatter of the next); then compound 4.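

Placing a hydroxy group on this aromatic carbon, para to a hydroxy group, costs inhibition: in the functional assay compound 3 gives 16000 nM and compound 4 gives 82000 nM and the step is a 5.1-fold higher number from compound 3 to compound 4 (0.71 log units; beyond the scatter) and so gives a weaker inhibitor, the first change here to go beyond the scatter. In a physicochemical assay for solubility, using the shake flask method, with a stated time of 12 h (on this read-out higher numbers stand for higher solubility and lower numbers for lower solubility), compound 3 gives 77000 nM and compound 4 gives 47000 nM and the same change gives a 1.6-fold lower number from compound 3 to compound 4 (0.21 log units; within the scatter) and so stays within the scatter. Nothing available explains the loss of inhibition. As far as these compounds go, whether a methoxy group or an amine on the same carbon would cost as much remains open. So does whether a hydroxy group would have this effect on the other compounds.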